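Methoxy for Methyl, Carried from One Core to Another

The compounds below may be only part of what the source reports. "The series", "measured", "known", "first", "only" and "open" are said of these compounds alone.

In an assay on isolated protein for inhibition of protein deacetylase HDAC6 (Homo sapiens), read by fluorescence, with stated times of 10 min and 2 h (on this read-out lower numbers stand for stronger inhibition and higher numbers for weaker inhibition), compound 1 `Cc1ccc(CN2CC(=O)N(Cc3ccc(C(=O)NO)cc3)C2=O)cc1` gives 17.6 nM and compound 2 `COc1ccc(CN2CC(=O)N(Cc3ccc(C(=O)NO)cc3)C2=O)cc1` gives 28.2 nM. The change between them is methoxy in place of methyl on an aromatic carbon, and it made a 1.6-fold higher number from compound 1 to compound 2 (0.20 log units; within the scatter). Compound 3 `Cc1ccc(CC2(c3ccccc3)NC(=O)N(Cc3ccc(C(=O)NO)cc3)C2=O)cc1` is built on a different core, and the difference between the two cores is not broken down here; in this assay compound 3 gives 82.4 nM, the highest of the three numbers, with compound 2 nearest and compound 1 furthest.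

Compound 4 `COc1ccc(CC2(c3ccccc3)NC(=O)N(Cc3ccc(C(=O)NO)cc3)C2=O)cc1` carries the same change on the core of compound 3: methoxy in place of methyl on an aromatic carbon. The surroundings of the changed carbon are described in the same words for both pairs, so this is the same change. Since the earlier step was a 1.6-fold higher number from compound 1 to compound 2 (0.20 log units; within the scatter), compound 4 is expected to show a 1.6-fold higher number from compound 3 to compound 4 (0.20 log units; within the scatter). Compound 4 is therefore estimated at 130 nM in this assay, with a likely range from 60 nM to 280 nM.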

Compound 4, half-maximal inhibitory concentration: 72.4 nM
The estimate for compound 4 lay 1.8-fold (0.25 log units) above the measured number, within the range that was stated.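

On the second core, methoxy in place of methyl on an aromatic carbon gave a 1.1-fold lower number from compound 3 to compound 4 (0.06 log units; within the scatter) in this assay. Set beside the earlier step, the two cores do not separate, and neither step on its own is a measurable change: the same change on two cores in this assay, a 1.6-fold higher number (0.20 log units; within the scatter) from compound 1 to compound 2 and a 1.1-fold lower number (0.06 log units; within the scatter) from compound 3 to compound 4, 1.8-fold (0.26 log units) apart, within the scatter of two such steps. This shows that, on these two cores, going from 4-methylbenzyl to 4-methoxybenzyl leaves the number within the scatter, but it rests on two pairs only and does not show that a change with a larger step would carry across in the same way.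

The compounds shown leave open whether other groups on the same aromatic carbon, such as a chlorine, an amine or a carboxylic acid, would also behave alike on both cores. They also leave open which part of the difference between the two cores bears on the numbers, and whether the same change would stay this small on a third core.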